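The compounds below may be only part of what the source reports. "The series", "measured", "known", "first", "only" and "open" are said of these compounds alone.

Measured so far in a functional assay on HepG2 cells (Homo sapiens) for cytotoxicity, read by MTT assay, with a stated time of 48 h; a higher number here means a weaker inhibitor, a lower number a stronger inhibitor:
compound 1 `CNC(=O)CSc1nc2ccc(NC(=O)c3ccccc3OC)cc2s1` gives 18500 nM;
compound 2 `CC(=O)Nc1ccc2nc(SCC(=O)NCc3ccccc3)sc2c1` gives 9200 nM;
compound 3 `O=C(CSc1nc2ccc(NC(=O)c3ccccc3)cc2s1)NCc1ccccc1` gives 34200 nM.

Compound 2 stands at the lowest of these three numbers, with compound 1 within the scatter of it and compound 3 beyond it. For the measured compounds named here, the one single-place step available is a 3.7-fold higher number from compound 2 to compound 3 (0.57 log units; beyond the scatter), which concerns the benzoyl end of the molecule rather than the amide tail. Going by the values given here, compound 4 `CNC(=O)CSc1nc2ccc(NC(C)=O)cc2s1` differs from compound 2 by hydrogen in place of phenyl on a saturated chain carbon bound to an amide-type nitrogen, a change at the other end; no measured pair isolates that tail change, since compound 1 and compound 3 differ in two places at once. Without a bearing step, a change in this assay of no more than the scatter is expected for compound 4, and its value is estimated at 12000 nM, between 5000 nM and 30000 nM, a step of a 1.3-fold higher number from compound 2 to compound 4 (0.12 log units; within the scatter).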

Compound 4, half-maximal inhibitory concentration: > 100000 nM
Compound 4: only a limit was reported; the forecaster's own chance of this, stated with the estimate: 5%; at least 8.3-fold (0.92 log units) between middle value and limit.
By their numbers in this assay, from the lowest: compounds 2, 1 and 3 (each within the scatter of the next, the first and the last beyond it). At a limit, above all of these: compound 4.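

In this assay, compound 4 is read only at a limit: the limit of > 100000 nM in this assay, at which 1 of the 4 values shown sits. For the compounds shown here, the benzylamino tail now proves to matter, since hydrogen in place of phenyl on a saturated chain carbon bound to an amide-type nitrogen gives an at least 10-fold higher number from compound 2 to compound 4 (1.03 log units; beyond the scatter) as the first reading at this position. With the methylamino tail, methyl in place of 2-methoxyphenyl gives an at least 5.4-fold higher number from compound 1 to compound 4 (0.73 log units; beyond the scatter) as its result, the opposite direction to the benzylamino series, where the phenyl carried the higher number. On these data alone, whether a longer chain such as phenethyl would behave like benzyl remains open. So does the effect of an amine or a carboxylic acid on this tail.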